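The source may report more compounds than this note shows. Statements on the series, on what has been measured and on what is new or still open speak of the compounds shown alone.

Measured so far:
- compound 1, `CN(C[C@H]1Cc2c(cccc2N2CCN3CCC[C@H]3C2)CN1)[C@H]1CCCc2cccnc21`: 2.92 nM
- compound 2, `CN(C[C@H]1Cc2c(cccc2N2CCN3CCC[C@@H]3C2)CN1)[C@H]1CCCc2cccnc21`: 3.59 nM

Both numbers come from a functional assay on CCRF-CEM cells for antagonist activity at C-X-C chemokine receptor type 4 (Homo sapiens), read by calcium flux, with stated times of 25 min and 90 s; on this read-out higher numbers stand for weaker inhibition and lower numbers for stronger inhibition. Compound 2 holds the higher of the two numbers, but the measured step is a 1.2-fold higher number from compound 1 to compound 2 (0.09 log units; within the scatter), so the pair cannot be ordered. Going by the values given here, the only measured step is this one, and it is built entirely on (the fact that compounds 1 and 2 differ only in the configuration as drawn); it says nothing about exchanging substituents on the aromatic ring.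

Compound 3, `CCN1CCN(c2cccc3c2C[C@H](CN(C)[C@H]2CCCc4cccnc42)NC3)CC1`, differs from compound 2 at exactly that place: a group of 8 heavy atoms (6 carbon, 2 nitrogen; one six-membered non-aromatic ring with 2 hetero atoms) in place of a group of 9 heavy atoms (7 carbon, 2 nitrogen; one five-membered non-aromatic ring with 1 hetero atom, one six-membered non-aromatic ring with 2 hetero atoms), on an aromatic carbon. Among the compounds with values here, no measured step touches a change of this kind, so no direction can be read off the two numbers in hand. The working assumption is therefore that the step from compound 2 to compound 3 in this assay stays close to the scatter, with the range widened to allow for an unobserved change in either direction. On that basis compound 3 is expected to give 6 nM (expected range 1.5 nM to 30 nM), which corresponds to an estimated step of a 1.7-fold higher number from compound 2 to compound 3 (0.22 log units; within the scatter).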

Compound 3, half-maximal inhibitory concentration: 13.8 nM
The estimate for compound 3 lay 2.3-fold (0.36 log units) below the measured number; the measured number falls inside the stated range.
By their numbers in this assay, from the lowest: compounds 1 and 2 (each within the scatter of the next); then compound 3.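

In this assay, exchanging the two-ring group of compounds 1 and 2 for 4-ethylpiperazin-1-yl on this aromatic carbon gives a step beyond the scatter from either starting point, a 3.8-fold higher number from compound 2 to compound 3 (0.58 log units; beyond the scatter) and a 4.7-fold higher number from compound 1 to compound 3 (0.67 log units; beyond the scatter), so the position is not indifferent to this change, although the steps are modest. The two steps amount to one exchange seen twice, and they can be read together: the fact that compounds 1 and 2 differ only in the configuration as drawn. Compound 3 still gives 13.8 nM, so with 4-ethylpiperazin-1-yl at this position the series keeps inhibition in the nanomolar range, while the stereocentre in the leaving group gave only a step within the scatter, a 1.2-fold higher number from compound 1 to compound 2 (0.09 log units; within the scatter).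

The compounds shown do not separate the loss of the five-membered ring from the presence of the ethyl group, since a single exchange changes both at once. A piperazine carrying a methyl group or a longer chain such as propyl, or an unsubstituted piperazine, would show whether the ethyl group or the ring pattern accounts for the step.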